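This account rests on a few compounds, and the source may have more. Where it says the series, first, only, none or still open, it means among the compounds named here.

- compound 1 `CCCCCCCC[C@@]1(C)SC(=O)C=C1OCC(=O)O` gives 13.8 ug/mL
- compound 2 `CCCCCCCC[C@@]1(C)SC(=O)C=C1OC(=O)OCC` gives 14.5 ug/mL

In a functional assay on MCF7 cells (Homo sapiens) for inhibition (a higher number here means a weaker inhibitor, a lower number a stronger inhibitor), compound 2 gives 14.5 ug/mL and compound 1 gives 13.8 ug/mL so the two sit within the scatter of each other, and neither can be ranked above the other. Compound 3 `C=CCOC(=O)OC1=CC(=O)S[C@]1(C)CCCCCCCC` differs from compound 2 in one place (vinyl in place of methyl on a saturated chain carbon bound to an oxygen next to a carbonyl group): vinyl in place of methyl on a saturated chain carbon bound to an oxygen next to a carbonyl group, which turns ethoxycarbonyl into allyloxycarbonyl. For the measured compounds named here, no measured step covers this exact change. Going by the values given here, the only step available, a 1.1-fold higher number from compound 1 to compound 2 (0.02 log units; within the scatter), exchanged carboxymethyl for ethoxycarbonyl and stayed within the scatter. On that evidence, the expected result in this assay is no real shift, with an estimated 1.0-fold lower number from compound 2 to compound 3 (0.02 log units; within the scatter) that stays inside the scatter. Compound 3 is expected at about 14 ug/mL with an estimated range from 8 ug/mL to 24 ug/mL for this measurement.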

Compound 3, half-maximal inhibitory concentration: 14.2 ug/mL
For compound 3 the middle estimate is 1.0-fold (0.01 log units) below the measured one, within the range that was stated.
By their numbers in this assay, from the lowest: compounds 1, 3 and 2 (each within the scatter of the next).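

In this assay, replacing ethoxycarbonyl with allyloxycarbonyl, which puts vinyl in place of methyl on a saturated chain carbon bound to an oxygen next to a carbonyl group, stays within the scatter (a 1.0-fold lower number from compound 2 to compound 3 (0.01 log units; within the scatter)). Set against carboxymethyl, allyloxycarbonyl also stays within the scatter (a 1.0-fold higher number from compound 1 to compound 3 (0.01 log units; within the scatter)), so this spot has now carried a double bond outside aromatic rings with no readable difference among the three compounds. No supporting data bear on why this result arises.

The compounds shown leave open whether an amine or a phenyl ring on that oxygen would give a reading beyond the scatter. They also leave open how a shorter or longer chain elsewhere on the shared core would read in this assay.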